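Chloro on the phenyl ring of two cores

The source may report more compounds than this note shows. Statements on the series, on what has been measured and on what is new or still open speak of the compounds shown alone.

Two cores are compared, each carrying a phenyl ring that is either unsubstituted or bears one chloro. Compound 1 `O=c1[nH]nc2n(c1=O)CCN2c1ccccc1` gives 30% in an ADME assay on Vero cells (Chlorocebus sabaeus) for cytotoxicity, with a stated time of 72 h, tested at 50 ug/mL; a lower number here means a weaker effect, a higher number a stronger effect of the compound at the concentration tested. Compound 3 `O=c1[nH]nc2n(c1=O)CCN2c1ccc(Cl)cc1` differs from compound 1 by chloro in place of hydrogen on an aromatic carbon. In this assay compound 3 gives 7%. That gives the step of a number 23 percentage points lower from compound 1 to compound 3 (beyond the scatter). Compound 2 `N/N=C1\NCCN1c1ccccc1` belongs to the second core; the difference between the two cores is not broken down here. In this assay compound 2 gives 0%, the lowest of the three numbers, with compound 3 within the scatter of it and compound 1 beyond it.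

Compound 4 `N/N=C1\NCCN1c1cccc(Cl)c1` differs from compound 2 by chloro in place of hydrogen on an aromatic carbon. This is the same kind of change as from compound 1 to compound 3, not the same: there the chloro sits para to a large group, here meta to a group of 7 heavy atoms. Compound 2 gives 0% in this assay, so a lowering of the size of a number 23 percentage points lower from compound 1 to compound 3 (beyond the scatter) has little room to show for compound 4. The step from compound 2 to compound 4 is therefore expected to be near zero, a number 2 percentage points higher from compound 2 to compound 4 (within the scatter). Compound 4 is expected to give 2%, estimated between 0% and 12%.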

Compound 4, a percentage reported as inhibition, at one concentration (the size of the read-out at that concentration, not a potency): 10%
For compound 4 the middle estimate is 8 percentage points below the measured one; the range from low to high includes it.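

In this assay, the step for chloro in place of hydrogen on an aromatic carbon does not carry over from one core to the other: the same change on two cores in this assay, a number 23 percentage points lower (beyond the scatter) from compound 1 to compound 3 and a number 10 percentage points higher (within the scatter) from compound 2 to compound 4, 33 percentage points apart, beyond the scatter of two such steps

On the core of compound 2, the step is a number 10 percentage points higher from compound 2 to compound 4 (within the scatter), so the lowering seen on the core of compound 1 does not appear here. This does not show that the core alone sets the outcome: the chloro of compound 4 sits meta to a group of 7 heavy atoms, while compound 3 carries its chloro at a different place on the ring, and the parent compound 2 already gives 0%.

The compounds shown leave open whether chloro at one and the same place on the ring would give matching steps on the two cores. Also open, as far as these compounds go, is whether another group on the phenyl ring, such as a methoxy group, an amine or a carboxylic acid, would follow either step.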